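The source may report more compounds than this note shows. Statements on the series, on what has been measured and on what is new or still open speak of the compounds shown alone.

Measured compounds in the series:

- compound 1 `CCCCS(=O)(=O)N1CCC2(CC1)OOC1(CCCC1)OO2`; in a functional assay on Huh-7 cells (Homo sapiens) for cytotoxicity, read by MTT assay, with a stated time of 72 h (a higher number here means that more compound is tolerated, a lower number that less compound is tolerated), compound 1 gives > 100 ug/mL, which is a limit of the assay and not a number.
- compound 2 `CCCCS(=O)(=O)N1CCC2(CC1)OOC1(CCCCC1)OO2`; in this assay compound 2 gives > 100 ug/mL, again a limit of the assay.
- compound 3 `O=S(=O)(CCCCl)N1CCC2(CC1)OOC1(CCCC1)OO2`; in this assay compound 3 gives > 100 ug/mL, also a limit of the assay.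

All three values sit at the limit of > 100 ug/mL in this assay, at which 3 of the 3 values shown sit, so no ordering among them can be read. The change from compound 1 to compound 3 is chloro in place of methyl on a saturated chain carbon, three bonds along the chain from a sulfonyl sulfur. The resulting step, a step that the two limits leave unreadable from compound 1 to compound 3, is unreadable because both ends sit at the limit of > 100 ug/mL in this assay, at which 3 of the 3 values shown sit. Compound 2 carries a different core from compound 1; the difference between the two cores is not broken down here.

Compound 4 `O=S(=O)(CCCCl)N1CCC2(CC1)OOC1(CCCCC1)OO2` is not yet measured. It differs from compound 2 by chloro in place of methyl on a saturated chain carbon, three bonds along the chain from a sulfonyl sulfur, the same change as from compound 1 to compound 3. The expected step in this assay is a number no higher from compound 2 to compound 4 (the limit leaves the size open), which rests on compound 1 and compound 3 both sitting at the limit of > 100 ug/mL in this assay, at which 3 of the 3 values shown sit, with a step that the two limits leave unreadable from compound 1 to compound 3 unreadable. Compound 4 is therefore estimated at 100 ug/mL, with a range from 50 ug/mL to 200 ug/mL, and a limit rather than a number is the more likely outcome.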

Compound 4, half-maximal cytotoxic concentration: > 100 ug/mL
Compound 4 was reported as a limit; the forecaster's own chance of this, stated with the estimate: 85%; the middle value sits exactly at the limit.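

In this assay compound 4 gives > 100 ug/mL, a limit of the assay and not a number. No step from compound 2 to compound 4 can be read, because both ends sit at the same limit: the limit of > 100 ug/mL in this assay, at which 4 of the 4 values shown sit.

The compounds shown leave open where any of the four would fall as a number, and so whether chloro in place of methyl shifts the read-out at all.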